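Sulfonamide for methoxy on a weak dihydroindene imidazole core

This account rests on a few compounds, and the source may have more. Where it says the series, first, only, none or still open, it means among the compounds named here.

Compound 1 `COc1cccc2c1CCC2c1ncc[nH]1` is known only by a limit: in a functional assay on CHO cells for agonist activity at Alpha-1D adrenergic receptor (Homo sapiens), read by FLIPR and calcium flux (on this read-out higher numbers stand for an effect only at larger amounts of compound and lower numbers for an effect already at smaller amounts), compound 1 gives > 10000 nM, which is the assay limit and not a number. Compound 2 `COc1c(Cl)ccc2c1CCC2c1ncc[nH]1` is at the same limit, since in this assay compound 2 gives > 10000 nM. For the measured compounds named here, the one measured step, a step that the two limits leave unreadable from compound 1 to compound 2, therefore cannot be read; both values sit at the limit of > 10000 nM in this assay, at which 2 of the 2 values shown sit. Compound 3 `CCS(=O)(=O)Nc1cccc2c1CCC2c1ncc[nH]1` carries (ethylsulfonyl)amino in place of methoxy on an aromatic carbon. Going by the values given here, no measured step bears on this change, so no direction beyond the scatter is expected for a step that the limit leaves unreadable from compound 1 to compound 3. Compound 3 is estimated at 15000 nM, within 3000 nM to 60000 nM, most likely again only a limit.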

Compound 3, half-maximal effective concentration: > 10000 nM
Compound 3 ended at the assay's limit; the forecaster's own chance of this, stated with the estimate: 70%; the middle value does not contradict the limit.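

For the compounds shown here, compound 3 stays at the assay limit, as do compound 1 and compound 2, so no new step among them can be read: the limit of > 10000 nM in this assay, at which 3 of the 3 values shown sit. Still open, as far as these compounds go, is whether, in this assay, any compound on the shared core gives a measurable value rather than a limit.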